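The source may hold more compounds than are shown below. What is called first, only, known or untested is meant among the compounds shown, and "the series" means these compounds.

Measured compounds:
Compound 1, `COc1ccccc1N1CCN(CCCNc2ccncc2C(=O)N(C(C)C)C(C)C)CC1`, gives 251 nM.
Compound 2, `CN(C)C(=O)c1cccnc1NCCCN1CCN(c2ccccc2C#N)CC1`, gives 10 nM.

Both numbers come from a functional assay on aorta for antagonist activity at Alpha-1D adrenergic receptor (Rattus norvegicus); on this read-out lower numbers stand for tighter binding and higher numbers for weaker binding. Compound 2 holds the lower of the two values; in this assay compound 1 gives 251 nM, a higher number, and the gap between compound 1 and compound 2 lies beyond the usual scatter. Compound 1 and compound 2 differ in several places at once, so their gap cannot be tied to any one change and is reported only as what the two values show.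

The step followed here leads from compound 2 to compound 3, `CSc1ccccc1N1CCN(CCCNc2ncccc2C(=O)N(C)C)CC1`, which has not yet been measured in this assay. The change is confined to one place: methylsulfanyl in place of cyano on an aromatic carbon. Going by the values given here, nothing among the measured compounds isolates this exchange, so no measured step stands as a guide. Compound 3 is therefore expected to stay near compound 2, with a modest step of a 1.6-fold higher number from compound 2 to compound 3 (0.20 log units; within the scatter) that could fall in either direction and may not exceed the scatter. Compound 3 is estimated to give 16 nM, with a plausible range from 4 nM to 64 nM.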

Compound 3, dissociation constant: 31.6 nM
Estimate against measurement, compound 3: 2.0-fold (0.30 log units) below, within the range that was stated.
By their numbers in this assay, from the lowest: compound 2; then compound 3; then compound 1.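

In this assay, going by these compounds alone, the exchange of 2-cyanophenyl for 2-(methylsulfanyl)phenyl gives the first reading of a change confined to one place, a 3.2-fold higher number from compound 2 to compound 3 (0.50 log units; beyond the scatter). It shows that this aromatic carbon, ortho to a large group, is sensitive to which group it carries, even though the heavy-atom and hydrogen-bond acceptor counts are the same on both sides of the exchange. The step is modest, and no measurement shown here explains why these two groups give different values.

From the compounds shown here alone, the exchange is read on only one background, so it remains open whether the same step would appear on the core of compound 1, where the amide and the position of the ring nitrogen also differ. Going by these compounds, it is also open how a chlorine atom, a carboxylic acid or a longer chain such as ethylsulfanyl on this aromatic carbon would stand against nitrile and methylsulfanyl, and whether any such group would give a lower number than cyano does.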